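Chloro in place of trifluoromethyl: working notes

A few compounds are considered here, and "the series" means these few. Any claim that something is new, unique, unknown or untested is made for them only; others in the source may bear on it.

Measured and pending in a functional assay on the whole organism with Scenedesmus acutus as the target, with a stated time of 20 h (a lower number here means a stronger inhibitor, a higher number a weaker inhibitor), as follows
compound 1 `CC(Cl)/C=C/C(=O)N(Cc1ccc(C#N)cc1)CC(C)C` gives 15100 nM
compound 2 `CC(Cl)/C=C/C(=O)N(Cc1ccc(C(F)(F)F)cc1)CC(C)C` gives 49000 nM
compound 3 `CC(Cl)/C=C/C(=O)N(Cc1ccc(Cl)cc1)CC(C)C` is not yet measured

For the measured compounds named here, compound 2 at 49000 nM holds the higher of the two numbers so far. The move to compound 3 is chloro in place of trifluoromethyl on an aromatic carbon and places chloro in place of trifluoromethyl on an aromatic carbon, para to a large group. Going by the values given here, only one measured step bears on this change: a 3.2-fold higher number from compound 1 to compound 2 (0.51 log units; beyond the scatter) is modest and also involves trifluoromethyl on an aromatic carbon. Among the compounds with values here, a single step is a thin guide, so a small shift toward a lower number in this assay is expected, no larger than that step. The estimated move is a 1.6-fold lower number from compound 2 to compound 3 (0.21 log units; within the scatter) and its direction remains tentative. For compound 3 the estimated value is 30000 nM with an expected range from 12000 nM to 70000 nM for this measurement.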

Compound 3, half-maximal inhibitory concentration: 21900 nM
Compound 3: middle estimate off by 1.4-fold (0.14 log units), on the high side; measured number inside the range.
By their numbers in this assay, from the lowest: compounds 1 and 3 (each within the scatter of the next); then compound 2.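

In this assay, a second group at this position now separates from trifluoromethyl: chloro in place of it gives a 2.2-fold lower number from compound 2 to compound 3 (0.35 log units; beyond the scatter), so the higher number of compound 2 no longer rests on the comparison with cyano alone. Chloro in place of cyano gives a 1.5-fold higher number from compound 1 to compound 3 (0.16 log units; within the scatter), so these two groups cannot be told apart here, and among the three compounds only trifluoromethyl stands apart. Nothing at hand accounts for this difference between the groups.

As far as these compounds go, how an amine, a carboxylic acid or a plain hydrogen on the same aromatic carbon would read in this assay remains open. Also open, from the compounds shown here alone, is whether the step from trifluoromethyl to chloro keeps its direction and size when the isobutyl group on the shared core gives way to a longer chain.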